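A 3-Hydroxyphenyl to 4-Fluorobenzyl Swap, Awaiting Its Number

This account rests on a few compounds, and the source may have more. Where it says the series, first, only, none or still open, it means among the compounds named here.

Measured compounds:
compound 1 `Cc1ccc(Nc2nc(N)nc(COc3ccc4c(C)cc(=O)oc4c3)n2)cc1C`: 210 nM
compound 2 `Cc1cc(=O)oc2cc(OCc3nc(N)nc(Nc4cccc(O)c4)n3)ccc12`: "not determined" (no result reported)

Among the measured compounds shown here, in an assay on COS-7 cells for agonist activity at Free fatty acid receptor 1 (Homo sapiens), read by scintillation counting and inositol phosphate accumulation, with a stated time of 90 min (on this read-out lower numbers stand for an effect already at smaller amounts and higher numbers for an effect only at larger amounts of compound), compound 1 gives 210 nM, while for compound 2 no number exists, so compound 2 cannot be placed on this scale and no step to it can be sized. Compound 3 `Cc1cc(=O)oc2cc(OCc3nc(N)nc(NCc4ccc(F)cc4)n3)ccc12` differs from compound 2 by 4-fluorobenzyl in place of 3-hydroxyphenyl on a nitrogen on an aromatic ring. With compound 2 unmeasured, the direction of this change cannot be read from a shown step; only compound 1 offers a landmark, and compound 3 is expected to land near it or somewhat weaker. Compound 3 is estimated at 600 nM, within 120 nM to 3000 nM.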

Compound 3, half-maximal effective concentration: 7820 nM
Compound 3: the middle estimate sits 13-fold (1.12 log units) below what was measured, outside the stated range (above it).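

In this assay the group on a nitrogen on an aromatic ring proves decisive: 4-fluorobenzyl in place of 3,4-dimethylphenyl gives a large change beyond the scatter (a 37-fold higher number from compound 1 to compound 3 (1.57 log units; beyond the scatter)). So this position does not accept every aromatic group equally. The step from compound 2 cannot be read, and nothing shown here accounts for the change.

Where 3-hydroxyphenyl falls on this scale stays open. So does whether a 3,4-dimethylbenzyl group on that nitrogen would return the number toward that of compound 1.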